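Acetyl to Hydrogen on a Ring Nitrogen, Measured Twice

The source may report more compounds than this note shows. Statements on the series, on what has been measured and on what is new or still open speak of the compounds shown alone.

Four compounds share a core; compound 1 `COc1ccccc1-c1cc(=O)c2cc(NC(C)=O)ccc2o1` and compound 3 `COc1ccccc1-c1cc(=O)c2cc(N)ccc2o1` carry one form of it, while compound 2 `COc1cccc(-c2cc(=O)c3cc(NC(C)=O)ccc3o2)c1` and compound 4 `COc1cccc(-c2cc(=O)c3cc(N)ccc3o2)c1` carry another, and the difference between the two cores is not broken down here. They were run in an ADME assay on MT4 cells (Homo sapiens) for cytotoxicity, read by MTT assay, with a stated time of 4 days; a higher number here means that more compound is tolerated, a lower number that less compound is tolerated. Compound 1 gives 226000 nM. Compound 3 gives 198000 nM. For compound 2 only a limit is known, > 404000 nM, and its value sits at the limit of > 404000 nM in this assay, at which 1 of the 3 values shown sits. Compound 3 differs from compound 1 by hydrogen in place of acetyl on a nitrogen on an aromatic ring, and this produced a 1.1-fold lower number from compound 1 to compound 3 (0.06 log units; within the scatter). Compound 4 differs from compound 2 by the same change, (hydrogen in place of acetyl on a nitrogen on an aromatic ring), so it is the same kind of change at the same kind of place, now on the other core. Compound 4 has not yet been run in this assay. Because a 1.1-fold lower number from compound 1 to compound 3 (0.06 log units; within the scatter) was found on one core, the same change on the other core is expected to give an at least 1.0-fold lower number from compound 2 to compound 4 (0.02 log units; that floor lies within the scatter). Compound 4 is therefore estimated at 380000 nM, between 180000 nM and 800000 nM.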

Compound 4, half-maximal cytotoxic concentration: 247000 nM
Compound 4: middle estimate off by 1.5-fold (0.19 log units), on the high side, within the range that was stated.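

On the second core, putting hydrogen in place of acetyl on the ring nitrogen gives, in this assay, an at least 1.6-fold lower number from compound 2 to compound 4 (0.21 log units; that floor lies within the scatter). From the compounds shown here alone, compound 2 has only a limit, > 404000 nM, which is not a number, so this step is a floor and its true size is unknown: the limit of > 404000 nM in this assay, at which 1 of the 4 values shown sits. The floor and the earlier step both lie within the scatter, so neither core shows a clear effect so far, yet this does not establish that the change carries over unchanged from one core to the other: the same change on two cores in this assay, a 1.1-fold lower number (0.06 log units; within the scatter) from compound 1 to compound 3 and an at least 1.6-fold lower number (0.21 log units; that floor lies within the scatter) from compound 2 to compound 4; the limit leaves it open whether they differ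

Going by these compounds, only acetyl and hydrogen appear on this ring nitrogen here, so it remains open how a longer acyl chain or a sulfonamide at that place would read in this assay. On these data alone, it is also open whether the same change would read alike on a core bearing a different group in place of methoxy, such as a chlorine atom or a carboxylic acid.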